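Clearance at the amine nitrogen: compound 3 to compound 4

This account rests on a few compounds, and the source may have more. Where it says the series, first, only, none or still open, it means among the compounds named here.

compound 1 `Cc1ccc(NC(=O)[C@H]2CN(C)C[C@@H]2c2ccc(/C=C/C(=O)Nc3ccccc3N)cc2)cc1`: 62 mL/min/kg
compound 2 `Nc1ccccc1NC(=O)/C=C/c1ccc([C@H]2CN(C3COC3)C[C@@H]2C(=O)Nc2ccc(Cl)cc2)cc1`: 42 mL/min/kg
compound 3 `CC(C)(CO)N1C[C@H](C(=O)Nc2ccc(Cl)cc2)[C@@H](c2ccc(/C=C/C(=O)Nc3ccccc3N)cc2)C1`: 40 mL/min/kg

In an in vitro ADME assay on microsomes from liver (Mus musculus) for pharmacokinetics, read by LC-MS, with a stated time of 10 min, tested at 1 uM (a higher number here means faster removal of the compound, a lower number slower removal), compound 3 lies within the scatter of both compound 1 and compound 2, so no order can be read among the three values. Compound 4 `Nc1ccccc1NC(=O)/C=C/c1ccc([C@H]2CN(C3CCOCC3)C[C@@H]2C(=O)Nc2ccc(Cl)cc2)cc1` is the next to be read, and it differs from compound 3 at a single place: oxan-4-yl in place of 1-(hydroxymethyl)-1-methylethyl on an amine nitrogen in a ring. Among the compounds with values here, the one measured step at this nitrogen, a 1.1-fold lower number from compound 2 to compound 3 (0.02 log units; within the scatter), came with 1-(hydroxymethyl)-1-methylethyl in place of oxetan-3-yl. Within the data shown here, compound 1 differs from compound 2 and compound 3 in more than one place, so it gives no clean step for this comparison. Among the measured compounds shown here, no measured compound carries oxan-4-yl, so the data hold no direct reading of that group. For the measured compounds named here, with the step of a 1.1-fold lower number from compound 2 to compound 3 (0.02 log units; within the scatter) as the only guide, no step beyond the scatter is expected in this assay, and no direction can be given. The expected size of the change is a 1.1-fold higher number from compound 3 to compound 4 (0.04 log units; within the scatter). For compound 4 the estimated clearance is 44 mL/min/kg, with an expected range of 26 mL/min/kg to 70 mL/min/kg.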

Compound 4, clearance: 44 mL/min/kg
Compound 4: the middle estimate sits on the measured number at the digits printed, within the range that was stated.
By their numbers in this assay, from the lowest: compounds 3, 2, 4 and 1 (each within the scatter of the next).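

In this assay, the amine nitrogen in the ring now carries a group with a six-membered non-aromatic ring, with the (4-chlorophenyl)carbamoyl group and the rest of the core held constant. Oxan-4-yl gives a 1.1-fold higher number from compound 3 to compound 4 (0.04 log units; within the scatter) when it replaces 1-(hydroxymethyl)-1-methylethyl, and a 1.0-fold higher number from compound 2 to compound 4 (0.02 log units; within the scatter) when it replaces oxetan-3-yl. The three groups therefore cannot be told apart in this read-out, even though the change to oxan-4-yl removes the one hydrogen-bond donor of 1-(hydroxymethyl)-1-methylethyl, and no measurement shown offers an explanation for this result.

Going by these compounds, it remains open whether a chain ending in an amine, a carboxylic acid or a longer chain on this nitrogen would give a step beyond the scatter, since the three groups compared here each contain a single oxygen. The small methyl group on the nitrogen of compound 1 also cannot be read on its own, as compound 1 differs from the other compounds in more than one place.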